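A few compounds are considered here, and "the series" means these few. Any claim that something is new, unique, unknown or untested is made for them only; others in the source may bear on it.

Three compounds have been measured in a functional assay on P388 cells (Mus musculus) for cytotoxicity, read by MTT assay, with a stated time of 72 h; a higher number here means a weaker inhibitor, a lower number a stronger inhibitor:

Compound 1 `Cc1c(/N=C/c2cccc(O)c2)c(=O)n(-c2ccccc2)n1C` gives 437000000 nM in this assay.
Compound 2 `COc1cccc(/C=N/c2c(C)n(C)n(-c3ccccc3)c2=O)c1` gives 105000000 nM.
Compound 3 `Cc1c(/N=C/c2ccccc2)c(=O)n(-c2ccccc2)n1C` gives 240000000 nM.

All three share a core and differ only on the outer ring. Compound 2 has the lowest number of the three: the steps are a 4.2-fold lower number from compound 1 to compound 2 (0.62 log units; beyond the scatter) and a 2.3-fold higher number from compound 2 to compound 3 (0.36 log units; beyond the scatter), both beyond the scatter, though modest.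

Compound 4 `COc1cccc(/C=N/c2c(C)n(C)n(-c3ccccc3)c2=O)c1O` has not yet been measured. It differs from compound 2 by hydroxy in place of hydrogen on an aromatic carbon. The same kind of change has already been made once, from compound 3 to compound 1, (hydroxy in place of hydrogen on an aromatic carbon), and there it gave a 1.8-fold higher number from compound 3 to compound 1 (0.26 log units; within the scatter), a step within the scatter. The two starting cores differ by methoxy in place of hydrogen on an aromatic carbon. The places are not identical: in compound 1 the hydroxy sits meta to a large group, whereas in compound 4 it sits ortho to a large group and ortho to a methoxy group, so this is the same kind of change rather than the same change. For the measured compounds named here, with only one earlier example, the expectation for compound 4 is a step of a 1.5-fold higher number from compound 2 to compound 4 (0.18 log units; within the scatter), resting on the small step of a 1.8-fold higher number from compound 3 to compound 1 (0.26 log units; within the scatter) seen from compound 3 to compound 1. Compound 4 is therefore estimated at 160000000 nM, likely between 60000000 nM and 450000000 nM.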

Compound 4, half-maximal inhibitory concentration: 851000000 nM
The estimate for compound 4 lay 5.3-fold (0.73 log units) below the measured number; measured number above the stated range.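

In this assay, putting hydroxy in place of hydrogen on an aromatic carbon gave an 8.1-fold higher number from compound 2 to compound 4 (0.91 log units; beyond the scatter), so on this core the change makes a clearly weaker inhibitor. The size of the effect did not carry over from one core to the other: the same change on two cores in this assay, a 1.8-fold higher number (0.26 log units; within the scatter) from compound 3 to compound 1 and an 8.1-fold higher number (0.91 log units; beyond the scatter) from compound 2 to compound 4, 4.5-fold (0.65 log units) apart, beyond the scatter of two such steps. This does not show whether the core itself or the place of the hydroxy lies behind that gap, as compound 4 has it ortho to a large group and ortho to a methoxy group while compound 1 has it in a different place on the ring, and two pairs of compounds set no rule for the series.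

The compounds shown leave open whether a hydroxy in that same place, on the core of compound 3 without the methoxy, would give a step as large as the one seen here. They also leave open how an amine or a carboxylic acid would behave in that place on the ring.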